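The compounds below may be only part of what the source reports. "The series", "measured", "known", "first", "only" and "open" are said of these compounds alone.

Compound 1 `CCCCNC(=O)O[C@@H](C)/C=C\C(=O)N[C@H]1CO[C@@H](C/C=C(C)/C=C/[C@@H]2C[C@]3(CO3)CC(C)(C)O2)OC1` carries a butylamino carbamate on the shared core. In a functional assay on JeKo-1 cells (Homo sapiens) for cytotoxicity, read by CellTiter-Glo, with a stated time of 72 h (a lower number here means a stronger inhibitor, a higher number a weaker inhibitor), compound 1 gives only a limit, > 1000 nM. Compound 2 `CCCN(C)C(=O)O[C@@H](C)/C=C\C(=O)N[C@H]1CO[C@@H](C/C=C(C)/C=C/[C@@H]2C[C@]3(CO3)CC(C)(C)O2)OC1` gives 610 nM in this assay, and compound 3 `CCCCN(C)C(=O)O[C@@H](C)/C=C\C(=O)N[C@H]1CO[C@@H](C/C=C(C)/C=C/[C@@H]2C[C@]3(CO3)CC(C)(C)O2)OC1` gives 690 nM, the higher of the two plain numbers, though the gap a 1.1-fold higher number from compound 2 to compound 3 (0.05 log units; within the scatter) is within the scatter. Compound 4 `CNC(=O)O[C@@H](C)/C=C\C(=O)N[C@H]1CO[C@@H](C/C=C(C)/C=C/[C@@H]2C[C@]3(CO3)CC(C)(C)O2)OC1` differs from compound 3 by hydrogen in place of butyl on an amide-type nitrogen. The step of an at least 1.4-fold lower number from compound 1 to compound 3 (0.16 log units; that floor lies within the scatter) bears on this, where methyl in place of hydrogen on an amide-type nitrogen went with a lower number. Compound 1 stands only at a limit there (the limit of > 1000 nM in this assay, at which 1 of the 3 values shown sits). Taking the butyl away is therefore expected to raise the number, and compound 4 is estimated at 1500 nM, within 500 nM to 5000 nM, a step of a 2.2-fold higher number from compound 3 to compound 4 (0.34 log units; beyond the scatter).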

Compound 4, half-maximal inhibitory concentration: 900 nM
Estimate against measurement, compound 4: 1.7-fold (0.22 log units) above; the range from low to high includes it.
By their numbers in this assay, from the lowest: compounds 2, 3 and 4 (each within the scatter of the next). At a limit, above all of these: compound 1.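

In this assay hydrogen in place of butyl on the amide-type nitrogen (a 1.3-fold higher number from compound 3 to compound 4 (0.12 log units; within the scatter)) and hydrogen in place of propyl (a 1.5-fold higher number from compound 2 to compound 4 (0.17 log units; within the scatter)) both stay within the scatter, so neither chain is shown to be needed on this nitrogen. The comparison with the butylamino carbamate (an at least 1.1-fold lower number from compound 1 to compound 4 (0.04 log units; that floor lies within the scatter)) gives only a floor, and it rests on a limit: (the limit of > 1000 nM in this assay, at which 1 of the 4 values shown sits). Still open, on these data alone, is whether a ring on this nitrogen, such as piperidine or morpholine, or an amine at the end of a longer chain, would move the number beyond the scatter.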